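The source may report more compounds than this note shows. Statements on the series, on what has been measured and on what is new or still open speak of the compounds shown alone.

Working notes on the series. In a functional assay on CCRF-CEM cells (Homo sapiens) for antiproliferative activity, read by MTT assay, with a stated time of 72 h (on this read-out higher numbers stand for weaker inhibition and lower numbers for stronger inhibition), compound 1 (`O=C1O/C(=C\Cn2cnc3c(F)nc(F)c(Cl)c32)C(OCc2ccccc2)=C1OCc1ccccc1`) stands at "not determined" (no result reported) and so offers no number from which to measure a step. For the measured compounds named here, the only number so far comes from compound 2 (`COc1nc(OC)c2c(ccn2CCC2(O)NC(=O)C(OCc3ccccc3)=C2OCc2ccccc2)n1`), which gives 87000 nM in this assay and marks very weak inhibition.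

Compound 3 (`O=C1O/C(=C\Cn2cnc3ncc(Br)c-3c2)C(OCc2ccccc2)=C1OCc1ccccc1`) departs from compound 1 at one place (a group of 10 heavy atoms (6 carbon, 3 nitrogen, 1 bromine; one five-membered aromatic ring with 1 hetero atom, one six-membered aromatic ring with 2 hetero atoms) in place of a group of 12 heavy atoms (6 carbon, 3 nitrogen, 2 fluorine, 1 chlorine; one five-membered aromatic ring with 2 hetero atoms, one six-membered aromatic ring with 1 hetero atom), on a saturated chain carbon bound to a double-bonded chain carbon). The exchange sits on a saturated chain carbon bound to a double-bonded chain carbon, and the rest of compound 1 stays as it is.

Going by the values given here, no step between measured compounds is available, so the size of this change cannot be read from the data. With only compound 2 at 87000 nM as a reference, compound 3 is expected to land beyond the usual scatter on the side of stronger inhibition, an expectation that rests on one value and is correspondingly loose. In this assay the estimated value for compound 3 is 10000 nM with an expected range from 1500 nM to 60000 nM on repeated measurement.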

Compound 3, half-maximal inhibitory concentration: 12000 nM
For compound 3 the middle estimate is 1.2-fold (0.08 log units) below the measured one; the range from low to high includes it.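

No new step can be read, since in this assay compound 3 gives 12000 nM and compound 1 offers no number to set against it. The compounds shown leave open how exchanging the group on the saturated chain carbon changes antiproliferative activity. No available evidence bears on this result.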